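A fourth aryl amide heads toward the same cytotoxicity limit

The compounds below may be only part of what the source reports. "The series", "measured", "known", "first", "only" and "open" are said of these compounds alone.

Measured so far in an ADME assay on Karpas-1106P cells (Homo sapiens) for cytotoxicity; a higher number here means that more compound is needed for the effect, a lower number that less compound is needed:
compound 1 `Cc1ccc(S(=O)(=O)N[C@@H](CC(=O)NC(C)(C)C)C(=O)NCCNC(=O)c2cccc(O)c2)cc1`: > 11100 nM, a limit of the assay rather than a number.
compound 2 `Cc1ccc(S(=O)(=O)N[C@@H](CC(=O)NC(C)(C)C)C(=O)NCCNC(=O)c2cccc(C(C)C)c2)cc1`: > 11100 nM, again a limit.
compound 3 `Cc1ccc(S(=O)(=O)N[C@@H](CC(=O)NC(C)(C)C)C(=O)NCCNC(=O)c2ccc(F)c(F)c2)cc1`: > 11100 nM, again a limit.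

Compound 1 therefore stands nowhere in particular on the numbers shown: its reading in this assay is a limit, and the two companions sit at the same limit. The three steps between the measured compounds, a step that the two limits leave unreadable from compound 1 to compound 2, a step that the two limits leave unreadable from compound 1 to compound 3 and a step that the two limits leave unreadable from compound 2 to compound 3, are all unreadable for that reason, so none of them can be given a size or a direction.

Compound 4 `Cc1ccc(S(=O)(=O)N[C@@H](CC(=O)NC(C)(C)C)C(=O)NCCNC(=O)c2ccccn2)cc1` is the next in line. Its difference from compound 1 is pyridin-2-yl in place of 3-hydroxyphenyl on a carbonyl carbon. Going by the values given here, the measured steps that touch the same carbonyl carbon, from compound 1 to compound 3 and from compound 2 to compound 3, are both unreadable, so no step of known size bears on this change. Among the compounds with values here, the only guide is the limit of > 11100 nM in this assay, at which 3 of the 3 values shown sit. Because of the limit of > 11100 nM in this assay, at which 3 of the 3 values shown sit, compound 4 is expected to return a limit as well, with an estimate of 20000 nM and a range from 8000 nM to 60000 nM. The step from compound 1 to compound 4 is accordingly expected to read a step that the limit leaves unreadable from compound 1 to compound 4, that is, nothing resolvable beyond the scatter. What the assay actually reports for compound 4 is taken up next.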

Compound 4, half-maximal effective concentration: > 11100 nM
Compound 4 ended at the assay's limit; the forecaster's own chance of this, stated with the estimate: 85%; the middle value lies beyond the limit too.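

In this assay compound 4 gives > 11100 nM, a limit of the assay and not a number. No step joining compound 4 to compound 1, compound 2 or compound 3 can be read, because all four compounds share that limit: the limit of > 11100 nM in this assay, at which 4 of the 4 values shown sit.

The compounds shown leave open how these four compounds rank in this assay, and whether any group on this carbonyl carbon would give a measurable value.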